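Hydrogen for chloro on the aryl ring of compound 2

The compounds below may be only part of what the source reports. "The series", "measured", "known", "first", "only" and "open" are said of these compounds alone.

Measured compounds:
compound 1, `CC(=O)Nc1cc(-c2ccc(OC[C@@](C)(N)CC(C)C)c(F)c2)ccn1`, 0.8 nM
compound 2, `COC(=O)Nc1cc(-c2cnc(OC[C@@](C)(N)CC(C)C)c(Cl)c2)ccn1`, 0.4 nM
compound 3, `CC(=O)Nc1cc(-c2ccc(OC[C@@H](N)CC(C)C)c(C)c2)ccn1`, 0.4 nM

Of the compounds shown here, three have been tested in an assay on isolated protein for inhibition of AP2-associated protein kinase 1 (Homo sapiens), with a stated time of 3 h, in the presence of a further agent that is not named here; on this read-out higher numbers stand for weaker inhibition and lower numbers for stronger inhibition. Compound 2 gives 0.4 nM in this assay, a number that is level with compound 3 at the digits recorded and, together with compound 3, the lowest of the three. Compound 1 is the furthest from compound 2, yet its number is still within the scatter of repeated runs, so no order among the three can be stated.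

Compound 4, `COC(=O)Nc1cc(-c2ccc(OC[C@@](C)(N)CC(C)C)nc2)ccn1`, has not yet been measured in this assay. It differs from compound 2 in one place: hydrogen in place of chloro on an aromatic carbon. Among the compounds with values here, no pair of measured compounds shares this change, so there is no measured step to lean on. Because compound 2 stands at 0.4 nM, compound 4 is expected to land near it, with at most a small step toward weaker inhibition that may or may not exceed the scatter. The estimated step from compound 2 to compound 4 is a 3.0-fold higher number from compound 2 to compound 4 (0.48 log units; beyond the scatter). Compound 4 is therefore expected to give about 1.2 nM in this assay, in a range from 0.4 nM to 4 nM.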

Compound 4, half-maximal inhibitory concentration: 28 nM
Compound 4: the middle estimate sits 23-fold (1.37 log units) below what was measured; measured number above the stated range.
By their numbers in this assay, from the lowest: compounds 2, 3 and 1 (each within the scatter of the next); then compound 4.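

Taking the chloro off the aromatic carbon ortho to the (2-amino-2,4-dimethylpentyl)oxy group gives a 70-fold higher number from compound 2 to compound 4 (1.85 log units; beyond the scatter) in this assay, so this one atom carries a large share of the inhibition seen with compound 2. All three earlier compounds carry a group at this place, so they could not show what a bare aromatic carbon there would cost; this single change shows that hydrogen is poorly tolerated on this ring. No measurement shown here explains the size of the step.

The compounds shown leave open whether another group at this carbon, such as bromo, methoxy or nitrile, would match chloro on the frame of compound 2. They also leave open whether the same change would cost as much on the ring without a nitrogen.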